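The source may report more compounds than this note shows. Statements on the series, on what has been measured and on what is new or still open speak of the compounds shown alone.

Among the compounds with values here, in a functional assay on MCF7 cells (Homo sapiens) for cytotoxicity, read by MTT assay, with a stated time of 72 h (on this read-out higher numbers stand for weaker inhibition and lower numbers for stronger inhibition), compound 2 `O=C1c2c[n+]([O-])c3ccccc3c2C(=O)c2c1c1ccccc1n2CCCCN1CCNCC1` gives 12000 nM, the higher of the two numbers measured so far and thus the weaker inhibition of the pair. Within the data shown here, the only comparison available is compound 1 `CN1CCN(CCCCn2c3c(c4ccccc42)C(=O)c2c[n+]([O-])c4ccccc4c2C3=O)CC1`, which gives 100 nM.

Compound 3 `CCCCN1CCN(CCCCn2c3c(c4ccccc42)C(=O)c2c[n+]([O-])c4ccccc4c2C3=O)CC1` has not yet been measured. It departs from compound 2 with butyl in place of hydrogen on an amine nitrogen in a ring. Among the measured compounds shown here, one measured step bears on this change, and it involves hydrogen in place of methyl on an amine nitrogen in a ring: a 120-fold higher number from compound 1 to compound 2 (2.08 log units; beyond the scatter). This large step, read in reverse, suggests that replacing the hydrogen of compound 2 could bring a much lower number. For the measured compounds named here, it is a single pair, however, and no measured compound carries butyl, so methyl is only an imperfect guide.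

A large step toward a lower number is therefore expected in this assay, perhaps somewhat smaller than the measured one. The expected step is a 48-fold lower number from compound 2 to compound 3 (1.68 log units; beyond the scatter). For compound 3 the estimated value is 250 nM, with an expected range from 50 nM to 2500 nM.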

Compound 3, half-maximal inhibitory concentration: 6900 nM
For compound 3 the middle estimate is 28-fold (1.44 log units) below the measured one; the whole stated range lies below it.
By their numbers in this assay, from the lowest: compound 1; then compounds 3 and 2 (each within the scatter of the next).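

In this assay, butyl in place of hydrogen on the amine nitrogen in the ring gives a 1.7-fold lower number from compound 2 to compound 3 (0.24 log units; within the scatter), so the butyl compound and the unsubstituted compound stand within the scatter of each other. Set against the methyl compound, the butyl compound shows a 69-fold higher number from compound 1 to compound 3 (1.84 log units; beyond the scatter), so the large advantage seen with methyl at this position does not carry over to butyl. Of the three compounds, only the methyl compound stands apart, which makes this position sensitive to the exact group on the nitrogen rather than simply to whether a carbon chain is present there; nothing given here offers an explanation for the difference between methyl and butyl.

The three compounds leave open how the numbers run between methyl and butyl, with an ethyl or propyl group on this nitrogen, and whether a benzyl or acetyl group there would follow methyl or butyl. On these data alone, all the values shown come from this assay, so whether the same order holds in other cell lines also remains open.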